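Cinnamate esters on the shared core: halogen for methoxy

The compounds below may be only part of what the source reports. "The series", "measured", "known", "first", "only" and "open" are said of these compounds alone.

Compound 1 `CC(O)C1C(=O)NC1OC(=O)/C=C/c1ccc(Cl)cc1` and compound 2 `COc1ccc(/C=C/C(=O)OC2NC(=O)C2C(C)O)cc1` share one core and differ only in the group on the aromatic carbon. In a functional assay on A549 cells (Homo sapiens) for inhibition, read by MTT assay (a higher number here means a weaker inhibitor, a lower number a stronger inhibitor), compound 1 gives 1590 nM and compound 2 gives 1590 nM; the step of no change at the digits printed from compound 1 to compound 2 (within the scatter) shows that methoxy in place of chloro made no difference within the scatter. Compound 3 `CC(O)C1C(=O)NC1OC(=O)/C=C/c1ccc(Br)cc1` is reached from compound 2 by bromo in place of methoxy on an aromatic carbon. Among the compounds with values here, only the step from compound 1 to compound 2 bears on this, and it was flat, so no step beyond the scatter is expected, no change at the digits printed from compound 2 to compound 3 (within the scatter). Compound 3 is therefore estimated at 1590 nM in this assay, with a range of 800 nM to 3200 nM.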

Compound 3, half-maximal inhibitory concentration: 1590 nM
Beside the measured number, compound 3's estimate shows no gap at the digits printed; low and high end bracket the measured number.
By their numbers in this assay, from the lowest: compounds 1, 2 and 3 (each within the scatter of the next).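

In this assay bromo in place of methoxy, on an aromatic carbon para to a large group, gives no change at the digits printed from compound 2 to compound 3 (within the scatter) and bromo in place of chloro gives no change at the digits printed from compound 1 to compound 3 (within the scatter) at this same position. Methoxy, chloro and bromo now all read alike here, so the flat result extends to a second halogen and to a group with one heavy atom more or fewer. Nothing on hand explains this flat reading.

Going by these compounds, whether an amine, a carboxylic acid or a longer chain at this position would leave that level remains open. On these data alone, the shared core's other positions also remain untested by these three compounds.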